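Methoxycarbonyl to ethoxycarbonyl: expected step in clearance

This account rests on a few compounds, and the source may have more. Where it says the series, first, only, none or still open, it means among the compounds named here.

- compound 1 `COC(=O)[C@H]1CC[C@@H](n2/c(=N/C(=O)c3ccccc3)[nH]c3ccc(CN4CCCCC4)cc32)CC1` gives 85 mL.min-1.g-1
- compound 2 `CC(C)NC(=O)[C@H]1CC[C@@H](n2/c(=N/C(=O)c3ccc(F)c(F)c3)[nH]c3ccc(CN4CCC(C(C)(C)O)CC4)cc32)CC1` gives 60 mL.min-1.g-1
- compound 3 `CC(C)NC(=O)[C@H]1CC[C@@H](n2/c(=N/C(=O)c3ccc(F)c(Cl)c3)[nH]c3ccc(CN4CCC(C(C)(C)O)CC4)cc32)CC1` gives 83 mL.min-1.g-1
- compound 4 `CCOC(=O)[C@H]1CC[C@@H](n2/c(=N/C(=O)c3ccccc3)[nH]c3ccc(CN4CCCCC4)cc32)CC1` is not yet measured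

In an in vitro ADME assay on microsomes from liver (Homo sapiens) for metabolic stability (a higher number here means faster removal of the compound, a lower number slower removal), compound 1 stands at 85 mL.min-1.g-1, within the scatter of both other measured compounds. Compound 4 differs from compound 1 by methyl in place of hydrogen on a saturated chain carbon bound to an oxygen next to a carbonyl group (methoxycarbonyl to ethoxycarbonyl). Going by the values given here, no measured step covers this change. Among the compounds with values here, the only single-place step, a 1.4-fold higher number from compound 2 to compound 3 (0.14 log units; within the scatter), is chloro in place of fluoro on an aromatic carbon, so it bears only indirectly. No change beyond the scatter is expected in this assay, and the estimated step is a 1.1-fold higher number from compound 1 to compound 4 (0.02 log units; within the scatter). For compound 4 the expected value is 90 mL.min-1.g-1, with an estimated range of 55 mL.min-1.g-1 to 140 mL.min-1.g-1.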

Compound 4, intrinsic clearance in microsomes: 222 mL.min-1.g-1
Beside the measured number, compound 4's estimate is 2.5-fold (0.39 log units) below it, and the stated range ends below it.
By their numbers in this assay, from the lowest: compounds 2, 3 and 1 (each within the scatter of the next); then compound 4.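

In this assay, the ester position proves sensitive to a very small change: methyl in place of hydrogen, methoxycarbonyl to ethoxycarbonyl, gives a 2.6-fold higher number from compound 1 to compound 4 (0.42 log units; beyond the scatter). This is the only step shown that lies beyond the scatter, whereas chloro in place of fluoro on an aromatic carbon gives a 1.4-fold higher number from compound 2 to compound 3 (0.14 log units; within the scatter). No measurement at hand explains the rise in clearance.

Open, from the compounds shown here alone, is whether a longer chain, such as propoxycarbonyl, raises the number further. Also open, going by these compounds, is how a carboxylic acid at this place compares with either ester.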